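The compounds below may be only part of what the source reports. "The series", "measured", "known", "first", "only" and "open" are said of these compounds alone.

Measured compounds:
Compound 1 `CCOC(=O)N1CCC(N2CCC[C@@H](NC(=O)C3CCCC3)C2)CC1`: in a functional assay on CHO cells for agonist activity at muscarinic acetylcholine receptor M5 (Rattus norvegicus) (on this read-out lower numbers stand for an effect already at smaller amounts and higher numbers for an effect only at larger amounts of compound), compound 1 gives > 10000 nM, which is a limit of the assay and not a number.
Compound 2 `CCOC(=O)N1CCC(N2CCC[C@@H](NC(=O)c3cccs3)C2)CC1`: in this assay compound 2 gives > 10000 nM, also a limit.
Compound 3 `CCOC(=O)N1CCC(N2CCC[C@@H](NC(=O)c3cccc(F)c3)C2)CC1`: in this assay compound 3 gives > 10000 nM, again a limit.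

Compound 3 therefore stands where every value shown stands, at the point described by the limit of > 10000 nM in this assay, at which 3 of the 3 values shown sit; no number separates it from compound 1 or compound 2, and nothing marks any of the three as stronger or weaker. The unmeasured compound 4 `CCOC(=O)N1CCC(N2CCC[C@@H](NC(=O)c3ccc(F)cc3C)C2)CC1` differs from compound 3 in one place: 4-fluoro-2-methylphenyl in place of 3-fluorophenyl on a carbonyl carbon. The measured steps that bear on this change are those at the same carbonyl carbon, namely a step that the two limits leave unreadable from compound 1 to compound 2, a step that the two limits leave unreadable from compound 1 to compound 3 and a step that the two limits leave unreadable from compound 2 to compound 3. Each of them is unreadable because the limit of > 10000 nM in this assay, at which 3 of the 3 values shown sit, caps both ends, so none of them tells how large a change at this position can be, in either direction. With no readable step to build on, the plain expectation for compound 4 is that it behaves like the three measured compounds and is most likely reported only as a limit again. For compound 4 the estimated value in this assay is 15000 nM, with a range from 3000 nM to 60000 nM. The step this estimate means, a step that the limit leaves unreadable from compound 3 to compound 4, is expected to stay within the scatter.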

Compound 4, half-maximal effective concentration: > 10000 nM
Compound 4 was reported as a limit (the forecaster's own chance of this, stated with the estimate: 85%); the middle value does not contradict the limit.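

Within the data shown here, compound 4 is again reported only as a limit, so no step linking it to compound 1, compound 2 or compound 3 can be read, because all four share one point: the limit of > 10000 nM in this assay, at which 4 of the 4 values shown sit.

The compounds shown leave open whether any group on this carbonyl carbon changes the read-out, and by how much.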